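The source may report more compounds than this note shows. Statements on the series, on what has been measured and on what is new or still open speak of the compounds shown alone.

Measured compounds:
Compound 1 `COc1ccc(F)cc1CNCCCNc1ccnc2cc(Cc3cc(C)cc(C)c3)ccc12` gives 9.47.
Compound 2 `COc1ccc(F)cc1CNCCCNc1ccnc2cc(Cc3ccc(F)cc3)ccc12` gives 9.47.
Compound 3 `COc1ccc(F)cc1CNCCCNc1ccnc2cc(-c3ccc(C(C)(C)C)cc3)ccc12` gives 9.47.

All three values come from a physicochemical assay for acid dissociation. Compound 3 stands level with compounds 1 and 2 at the digits shown; its nearest neighbour is compound 1 and its furthest is compound 2, and in both cases the gap lies within the scatter.

The step to compound 4 `COc1ccc(F)cc1CNCCCNc1ccnc2cc(Oc3cccc(N(C)C)c3)ccc12` is 3-(dimethylamino)phenoxy in place of 4-(tert-butyl)phenyl on an aromatic carbon. The measured steps that bear on it all alter the same position on the shared core: no change at the digits printed from compound 1 to compound 2 (within the scatter), no change at the digits printed from compound 1 to compound 3 (within the scatter) and no change at the digits printed from compound 2 to compound 3 (within the scatter). Each of these exchanged one aryl or benzyl group for another at that aromatic carbon, and none moved the read-out beyond the scatter. The step to compound 4 also replaces the group at that carbon, so on the basis of these three steps no change beyond the scatter is expected in this assay; the estimated step is no change at the digits printed from compound 3 to compound 4 (within the scatter).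

Compound 4 is therefore expected to give 9.47, with a range from 9.15 to 9.8.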

Compound 4, acid dissociation constant: 9.28
Beside the measured number, compound 4's estimate is 0.19 log units above it; the range from low to high includes it.
By their numbers in this assay, from the lowest: compounds 4, 1, 2 and 3 (each within the scatter of the next).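

In this assay, among the compounds shown here, the 3-(dimethylamino)phenoxy group is the only one of the four groups at this aromatic carbon that carries nitrogen and oxygen, and it still gives a number 0.19 log units lower from compound 3 to compound 4 (within the scatter) and a number 0.19 log units lower from compound 2 to compound 4 (within the scatter) and a number 0.19 log units lower from compound 1 to compound 4 (within the scatter) as the steps to compound 4. The earlier compounds shown here showed this flat read-out only among groups attached directly or through a saturated carbon, whereas compound 4 extends it to an aryl group attached through oxygen, with 2 hydrogen-bond acceptors entering where the 4-(tert-butyl)phenyl group had none. No measurement here speaks to what lies behind these numbers.

As far as these compounds go, all four compounds keep an aromatic ring of carbon only at this position with no net charge, so it remains open whether a carboxylic acid or a piperazine there would shift the read-out beyond the scatter. These compounds also differ at this one carbon alone, which leaves open what an amide in place of the secondary amine of the side chain would do to the number in this assay.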